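The source may hold more compounds than are shown below. What is called first, only, known or untested is meant among the compounds shown, and "the series" means these compounds.

Working notes on the series. Compound 3 `Cc1cc(CCC#N)cc(C)c1Oc1cc(Nc2ccc(C#N)cc2)c(N)cc1N` stands at a limit of an ADME assay on TZM cells (Homo sapiens) for cytotoxicity, read by XTT assay, with a stated time of 4 days (on this read-out higher numbers stand for lower toxicity in this test and lower numbers for higher toxicity in this test), giving > 25000 nM. Compound 1 `Cc1cc(CCC#N)cc(C)c1Oc1cc(Nc2ccc(C#N)cc2)c(N)cc1C(N)=O` likewise stands at a limit, giving > 9400 nM in this assay. The step that the two limits leave unreadable from compound 1 to compound 3, amino in place of carbamoyl on an aromatic carbon, is unreadable because the limit of > 25000 nM in this assay, at which 1 of the 3 values shown sits, and the limit of > 9400 nM in this assay, at which 1 of the 3 values shown sits, cap both ends. Compound 2 `Cc1cc(/C=C/C#N)cc(C)c1Oc1cc(Nc2ccc(C#N)cc2)c(N)cc1C(=O)O`, which already carries the carboxy group, gives 14900 nM in this assay. Compound 4 `Cc1cc(CCC#N)cc(C)c1Oc1cc(Nc2ccc(C#N)cc2)c(N)cc1C(=O)O` differs from compound 3 by carboxy in place of amino on an aromatic carbon. Among the compounds with values here, no measured step bears on this change, so no direction beyond the scatter is expected; the value of compound 2 suggests the same unremarkable region. For compound 4 the estimate is 18000 nM, between 8000 nM and 40000 nM, a step of an at least 1.3-fold lower number from compound 3 to compound 4 (0.14 log units; that floor lies within the scatter) that is expected to stay within the scatter.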

Compound 4, half-maximal cytotoxic concentration: 14300 nM
Compound 4: middle estimate off by 1.3-fold (0.10 log units), on the high side, within the range that was stated.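

Carboxy on the aromatic carbon para to a (4-cyanophenyl)amino group gives a measured number in this assay, and the change from amino is an at least 1.7-fold lower number from compound 3 to compound 4 (0.24 log units; that floor lies within the scatter). On these data alone, the value of compound 3, > 25000 nM, is a limit, and the true size of this step stays unknown. With carboxy in place, 2-cyanoethyl in place of 2-cyanoethenyl gives a 1.0-fold lower number from compound 2 to compound 4 (0.02 log units; within the scatter), so these two chains are not told apart here. The step from compound 1 to compound 4 cannot be read. As far as these compounds go, whether a methyl ester or a sulfonamide at this position would stay in the same region remains open.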